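Opening the ring of compound 2

This account rests on a few compounds, and the source may have more. Where it says the series, first, only, none or still open, it means among the compounds named here.

Measured in a functional assay on H292 cells (Homo sapiens) for antiproliferative activity, read by MTT assay, with a stated time of 72 h; on this read-out higher numbers stand for weaker inhibition and lower numbers for stronger inhibition
Compound 1 `O=C(O)/C=C/c1ccc(-c2ccc(F)cc2)c(Cl)c1` gives 47000 nM
Compound 2 `CC1(c2cc(-c3ccc(/C=C/C(=O)O)cc3Cl)ccc2O)CCCCC1` gives 3900 nM

Of these two, compound 2 has the lower number, and the gap to compound 1 lies beyond the scatter. Compound 3 `CCC(CC)(CC)c1cc(-c2ccc(/C=C/C(=O)O)cc2Cl)ccc1O` differs from compound 2 by 1,1-diethylpropyl in place of 1-methylcyclohexyl on an aromatic carbon in one place: 1,1-diethylpropyl in place of 1-methylcyclohexyl on an aromatic carbon. Within the data shown here, no measured step covers this exchange, so no change beyond the scatter is expected in this assay and the expected 1.2-fold higher number from compound 2 to compound 3 (0.06 log units; within the scatter) is small. Compound 3 is estimated at 4500 nM (range 1800 nM to 11000 nM).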

Compound 3, half-maximal inhibitory concentration: > 5000 nM
Compound 3 ended at the assay's limit; the forecaster's own chance of this, stated with the estimate: 3%; middle value at least 1.1-fold (0.04 log units) away from the limit.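

In this assay compound 3 stops at a limit of the assay, > 5000 nM, and this is not a number. Among these compounds, the only reading is an at least 1.2-fold higher number from compound 2 to compound 3 (0.10 log units; that floor lies within the scatter), so opening the ring on this aromatic carbon, ortho to a hydroxy group, brought no stronger inhibition, while any real loss remains unproven. The read-out for this open-chain group therefore ends at a limit: the limit of > 5000 nM in this assay, at which 1 of the 3 values shown sits.

From the compounds shown here alone, how far compound 3 truly lies from compound 2 stays open. So does whether a tert-butyl group on this carbon, or an amine in place of the hydroxy group, would hold the inhibition.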